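Removing One Chloro Group from Compound 3

A few compounds are considered here, and "the series" means these few. Any claim that something is new, unique, unknown or untested is made for them only; others in the source may bear on it.

In an ADME assay on Vero 76 cells (Chlorocebus sabaeus) for cytotoxicity, read by crystal violet staining, with a stated time of 96 h (on this read-out higher numbers stand for lower toxicity in this test and lower numbers for higher toxicity in this test), compound 3 (`Fc1ccc(NC(=S)Nc2cccc(C(F)(F)F)c2)cc1Cl`) gives 20000 nM, compound 1 (`CCCC[C@H]1CC[C@H](c2ccc(NC(=S)Nc3cccc(C(F)(F)F)c3)cc2)CC1`) gives 17000 nM and compound 2 (`N#Cc1ccc(NC(=S)Nc2cccc(C(F)(F)F)c2)cc1`) gives 10000 nM. These three values lie within the usual scatter of one another, so compound 3 stands level with the other two.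

Compound 4 (`Fc1ccc(NC(=S)Nc2cccc(C(F)(F)F)c2)cc1`) has hydrogen in place of chloro on an aromatic carbon. For the measured compounds named here, the only measured single-place change put cyano in place of 4-butylcyclohexyl and gave a 1.7-fold lower number from compound 1 to compound 2 (0.23 log units; within the scatter), which is within the scatter. That swap involved a much larger group, so no step beyond the scatter is expected here. The expected change is a 1.3-fold lower number from compound 3 to compound 4 (0.10 log units; within the scatter). For compound 4 the estimated value is 16000 nM, with an expected range of 8000 nM to 30000 nM.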

Compound 4, half-maximal cytotoxic concentration: 40000 nM
Beside the measured number, compound 4's estimate is 2.5-fold (0.40 log units) below it; measured number outside the range, above it.
By their numbers in this assay, from the lowest: compounds 2, 1, 3 and 4 (each within the scatter of the next, the first and the last beyond it).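

In this assay, hydrogen in place of chloro ortho to a fluoro group gives a 2.0-fold higher number from compound 3 to compound 4 (0.30 log units; within the scatter) and so leaves the number within the scatter at this position. For the compounds shown here, the fluoro compound also yields the first steps beyond the scatter, both modest: fluoro in place of cyano gives a 4.0-fold higher number from compound 2 to compound 4 (0.60 log units; beyond the scatter) and fluoro in place of 4-butylcyclohexyl gives a 2.4-fold higher number from compound 1 to compound 4 (0.37 log units; beyond the scatter). No measurement given here explains these steps.

As far as these compounds go, whether a methoxy group or an amine at the chloro position would keep this number remains open. So does the outcome of replacing the fluoro group with hydrogen.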